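This account rests on a few compounds, and the source may have more. Where it says the series, first, only, none or still open, it means among the compounds named here.

Measured in a functional assay on MKN-45 cells (Homo sapiens) for cytotoxicity, read by MTT assay, with a stated time of 72 h; a lower number here means a stronger inhibitor, a higher number a weaker inhibitor:
Compound 1 `CN(C)CCNc1nc(-c2ccc(NC(=O)Nc3ccccc3F)cc2)nc2ccsc12` — 530 nM
Compound 2 `CN(C)CCNc1nc(-c2ccc(NC(=O)Nc3ccccc3Cl)cc2)nc2ccsc12` — 850 nM

Compound 2 has the higher of the two numbers in this assay, though the step of a 1.6-fold higher number from compound 1 to compound 2 (0.21 log units; within the scatter) lies within the scatter. Compound 3 `CCN(CC)CCCNc1nc(-c2ccc(NC(=O)Nc3ccccc3Cl)cc2)nc2ccsc12` differs from compound 2 by (diethylamino)methyl in place of dimethylamino on a saturated chain carbon, two bonds along the chain from a nitrogen on an aromatic ring. Among the measured compounds shown here, the only measured step, chloro in place of fluoro, a 1.6-fold higher number from compound 1 to compound 2 (0.21 log units; within the scatter), does not touch the dimethylamino end of the chain, so nothing on record bears on this change. No movement beyond the scatter is expected, and a wide range is kept. Compound 3 is therefore estimated at 850 nM (range 300 nM to 2500 nM), an expected step of no change at the digits printed from compound 2 to compound 3 (within the scatter).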

Compound 3, half-maximal inhibitory concentration: 390 nM
For compound 3 the middle estimate is 2.2-fold (0.34 log units) above the measured one; measured number inside the range.
By their numbers in this assay, from the lowest: compounds 3, 1 and 2 (each within the scatter of the next, the first and the last beyond it).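

Exchanging the (2-(dimethylamino)ethyl)amino group for (3-(diethylamino)propyl)amino moves the number in this assay beyond the scatter (a 2.2-fold lower number from compound 2 to compound 3 (0.34 log units; beyond the scatter)), so this end of the chain registers a change where the earlier chloro for fluoro step stayed within it. The step is modest, and it alters the chain and the amine substituents together. Nothing on record accounts for the shift. Going by these compounds, whether the propyl chain or the ethyl groups on the amine carry the step stays open. So does the outcome with a ring amine such as morpholine at the chain end.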